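Sulfonamide Partners on a Weak Antiproliferative Thiourea Core

A few compounds are considered here, and "the series" means these few. Any claim that something is new, unique, unknown or untested is made for them only; others in the source may bear on it.

Measured so far:
Compound 1 `Cc1cc(NS(=O)(=O)c2ccc(N/C(S)=N\c3ccnc4cc(C(F)(F)F)ccc34)cc2)on1`: 28500 nM
Compound 2 `Cc1ccnc(NS(=O)(=O)c2ccc(N/C(S)=N\c3ccnc4cc(C(F)(F)F)ccc34)cc2)n1`: "not active" (no number reported)

Both compounds share one core and differ only in the ring attached to the sulfonamide nitrogen. In a functional assay on HepG2 cells (Homo sapiens) for antiproliferative activity, read by sulforhodamine B assay, with a stated time of 48 h (on this read-out higher numbers stand for weaker inhibition and lower numbers for stronger inhibition), compound 1 gives 28500 nM, a weak result on this read-out. Compound 2 was reported as "not active" (no number reported) in this assay, without a number, so it stands at or beyond the weak end of what the assay can resolve, and no size can be attached to the gap between the two.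

Compound 3 `COc1ncnc(NS(=O)(=O)c2ccc(N/C(S)=N\c3ccnc4cc(C(F)(F)F)ccc34)cc2)c1OC` has not yet been measured. It differs from compound 2 by 5,6-dimethoxypyrimidin-4-yl in place of 4-methylpyrimidin-2-yl on a sulfonamide nitrogen. Among the compounds with values here, no measured pair shows what such an exchange on the sulfonamide nitrogen does, and the only neighbouring data are two weak or inactive compounds. The expectation for compound 3 is therefore a result that stays in the weak range, with a real chance that this assay again reports only a limit rather than a number. Compound 3 is estimated at 40000 nM, with a range from 10000 nM to 150000 nM.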

Compound 3, half-maximal inhibitory concentration: 77300 nM
Estimate against measurement, compound 3: 1.9-fold (0.29 log units) below; the range from low to high includes it.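

In this assay, within the data shown here, exchanging the ring on the sulfonamide nitrogen changes the result by a measurable amount: 5,6-dimethoxypyrimidin-4-yl in place of 3-methyl-1,2-oxazol-5-yl gives a 2.7-fold higher number from compound 1 to compound 3 (0.43 log units; beyond the scatter) as the first step with a size at this position, a modest weakening that still stays in the weak range. Compound 3 has a number while compound 2 has none, which shows that a 5,6-dimethoxypyrimidin-4-yl partner remains within what this read-out can report, but the step from compound 2 to compound 3 cannot be read. No measurement at hand accounts for the shift or links it to any feature of these groups.

The compounds shown leave open whether any partner on the sulfonamide nitrogen can bring the result out of the weak range, for example an open-chain amine or a carboxylic acid in place of the ring. Among these compounds, they also leave open whether the two methoxy groups of compound 3 matter on their own, as no pair here changes them alone.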